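Ethyl to Fluoro: Expected Effect on Receptor Inhibition

The source may hold more compounds than are shown below. What is called first, only, known or untested is meant among the compounds shown, and "the series" means these compounds.

Of the compounds shown here, two sharing a core have been measured in an in vitro functional assay on HEK293-A cells for agonist activity at metabotropic glutamate receptor 5 (Rattus norvegicus), read by ELISA; a lower number here means a stronger inhibitor, a higher number a weaker inhibitor. Compound 1 `CCc1cccc(C#Cc2cccc(C#N)c2)n1` gives 80 nM, the lowest of the two numbers. Compound 2 `CC(=O)c1cccc(C#Cc2cc(F)cc(C#N)c2)n1` gives 240 nM, a gap beyond the usual scatter, although compound 2 differs from compound 1 in more than one place. Compound 3 `N#Cc1cccc(C#Cc2cccc(F)n2)c1` is not yet measured; it differs from compound 1 by fluoro in place of ethyl on an aromatic carbon. Within the data shown here, no single-change step is available to guide the size of this effect, so only a moderate rise in the number, near the edge of the scatter, is expected. Compound 3 is estimated at 200 nM, with a range from 60 nM to 700 nM, which amounts to an expected step of a 2.5-fold higher number from compound 1 to compound 3 (0.40 log units; beyond the scatter).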

Compound 3, half-maximal inhibitory concentration: 210 nM
Estimate against measurement, compound 3: 1.1-fold (0.02 log units) below; measured number inside the range.
By their numbers in this assay, from the lowest: compound 1; then compounds 3 and 2 (each within the scatter of the next).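

Read on its own for the first time, fluoro in place of ethyl on an aromatic carbon next to the ring nitrogen gives, in this assay, a 2.6-fold higher number from compound 1 to compound 3 (0.42 log units; beyond the scatter) as a modest step. Ethyl is therefore not essential for activity, since compound 3 still gives 210 nM in the nanomolar range, though the smaller fluoro does not match it. Nothing available explains why this swap raises the number. As far as these compounds go, only these two groups can be compared at this position, so how a methyl, a methoxy or an amine would behave there remains open.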